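Swapping a Pyrazole for a Fluoropyridine on the Shared Core

The source may hold more compounds than are shown below. What is called first, only, known or untested is meant among the compounds shown, and "the series" means these compounds.

Compound 1 `COc1ccc(CNC(=O)c2cc(-c3cncc(C)c3)ncc2-c2cnn(C)c2)nc1OC` is the weaker of the two measured compounds: in an assay on CHO cells for antagonist activity at Orexin receptor type 2 (Homo sapiens), read by FLIPR, with a stated time of 5 min (on this read-out lower numbers stand for stronger inhibition and higher numbers for weaker inhibition), compound 1 gives 167 nM, while compound 2 `COc1ccc(CNC(=O)c2cc(-c3cncc(C)c3)ccc2-c2ccccc2)nc1OC` gives 14 nM, a gap that lies beyond the usual scatter. Compound 3 `COc1ccc(CNC(=O)c2cc(-c3cncc(C)c3)ncc2-c2cncc(F)c2)nc1OC` has not yet been measured; it differs from compound 1 in one place, (5-fluoropyridin-3-yl in place of 1-methyl-1H-pyrazol-4-yl on an aromatic carbon). Among the compounds with values here, no measured pair shows this exact change, so the expected step of a 1.7-fold lower number from compound 1 to compound 3 (0.22 log units; within the scatter) is a modest one toward a lower number, possibly no larger than the scatter. For compound 3 the estimate in this assay is 100 nM, with a likely range from 30 nM to 350 nM.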

Compound 3, half-maximal inhibitory concentration: 57 nM
The estimate for compound 3 lay 1.8-fold (0.24 log units) above the measured number; measured number inside the range.
By their numbers in this assay, from the lowest: compound 2; then compound 3; then compound 1.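

On this aromatic carbon, ortho to a large group, the choice of ring matters: in this assay putting 5-fluoropyridin-3-yl in place of 1-methyl-1H-pyrazol-4-yl gives a 2.9-fold lower number from compound 1 to compound 3 (0.47 log units; beyond the scatter) as a modest step beyond the scatter. The position therefore accepts this six-membered aromatic ring with no loss against the five-membered one. Nothing available explains why the number falls. As far as these compounds go, whether the fluorine or the ring itself accounts for the step stays open, as does how an amine or a carboxylic acid would fare on this carbon.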